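The source may hold more compounds than are shown below. What is called first, only, known or untested is meant among the compounds shown, and "the series" means these compounds.

Compound 1 `O=c1[nH]cnc2c1c(-c1ccccc1)cn2-c1ccc(S(=O)(=O)Nc2nccs2)cc1` and compound 2 `O=c1[nH]cnc2c1c(-c1ccccc1)cn2-c1ccc(S(=O)(=O)Nc2ccccn2)cc1` share one core, and in a functional assay on MCF7 cells (Homo sapiens) for inhibition, read by sulforhodamine B assay, with a stated time of 24 h (a lower number here means a stronger inhibitor, a higher number a weaker inhibitor), compound 1 gives 6210 nM while compound 2 gives 5320 nM. The two differ only in pyridin-2-yl in place of 1,3-thiazol-2-yl on a sulfonamide nitrogen, and that change gave a 1.2-fold lower number from compound 1 to compound 2 (0.07 log units; within the scatter). Compound 3 `CC(=O)Nc1c(C#N)c(-c2ccccc2)cn1-c1ccc(S(=O)(=O)Nc2nccs2)cc1` carries a different core; the difference between the two cores is not broken down here. In this assay compound 3 gives 7240 nM, a number within the scatter of both compound 1 and compound 2. Compound 4 `CC(=O)Nc1c(C#N)c(-c2ccccc2)cn1-c1ccc(S(=O)(=O)Nc2ccccn2)cc1`, not yet measured, differs from compound 3 by pyridin-2-yl in place of 1,3-thiazol-2-yl on a sulfonamide nitrogen, the same change seen from compound 1 to compound 2. Since that change gave a 1.2-fold lower number from compound 1 to compound 2 (0.07 log units; within the scatter), compound 4 is expected to give a 1.2-fold lower number from compound 3 to compound 4 (0.08 log units; within the scatter). The estimate for compound 4 in this assay is therefore 6000 nM, between 3000 nM and 12000 nM.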

Compound 4, half-maximal inhibitory concentration: 11800 nM
Compound 4: the middle estimate sits 2.0-fold (0.29 log units) below what was measured; the range from low to high includes it.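

In this assay, putting pyridin-2-yl in place of 1,3-thiazol-2-yl on the sulfonamide nitrogen of the core of compound 3 gave a 1.6-fold higher number from compound 3 to compound 4 (0.21 log units; within the scatter). Set beside the same change on the core of compound 1, this step shows no difference between the two cores: the same change on two cores in this assay, a 1.2-fold lower number (0.07 log units; within the scatter) from compound 1 to compound 2 and a 1.6-fold higher number (0.21 log units; within the scatter) from compound 3 to compound 4, 1.9-fold (0.28 log units) apart, within the scatter of two such steps. Since each step lies within the scatter, the two cores give no sign that the change has a real effect on either one, and a single pair of steps cannot show that it would carry the same way to other cores in the series.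

Still open, from the compounds shown here alone, is whether a different group on that sulfonamide nitrogen, such as a methyl or a pyrimidin-2-yl, would move the number beyond the scatter on either core.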